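The source may hold more compounds than are shown below. What is called first, only, known or untested is meant among the compounds shown, and "the series" means these compounds.

In a functional assay on MDA-MB-435 cells (Homo sapiens) for inhibition, read by sulforhodamine B assay, with a stated time of 48 h (on this read-out lower numbers stand for stronger inhibition and higher numbers for weaker inhibition), the measured compounds stand as follows:

Compound 1 `COc1ccc(N(C)c2nc(C)nc3c2CCC3)cc1` gives 7 nM
Compound 2 `CN(c1ccc(Cl)cc1)c1ncnc2c1CCC2` reads "not determined" (no result reported)
Compound 3 `COc1cccc(N(C)c2nc(N)nc3c2CCC3)c1` gives > 1000 nM as a limit and not a number

Compound 2 has no number of its own: its entry reads "not determined" (no result reported) and so it cannot be ranked against the others. Compound 4 `COc1ccc(N(C)c2ncnc3c2CCC3)cc1` has not yet been measured. Methoxy takes the place of chloro on an aromatic carbon, para to a large group, in the step methoxy in place of chloro on an aromatic carbon and the rest of the structure stays the same.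

Compound 1 also carries a methoxy and gives 7 nM in this assay and this is the main support for expecting strong inhibition. Compound 3 goes against that reading: it also carries a methoxy, and its > 1000 nM is a limit. The step has no measured starting point, but a move toward stronger inhibition, beyond the usual scatter, is expected. The estimated value for compound 4 is 30 nM with an expected range of 7 nM to 200 nM as a working expectation.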

Compound 4, half-maximal inhibitory concentration: 43 nM
Estimate against measurement, compound 4: 1.4-fold (0.16 log units) below; measured number inside the range.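

In this assay, compound 4 keeps a nanomolar value of 43 nM without the methyl of compound 1, but the step of a 6.1-fold higher number from compound 1 to compound 4 (0.79 log units; beyond the scatter) shows that hydrogen in place of that methyl on an aromatic carbon of the shared core does change the read-out. The change from chloro to methoxy itself cannot be read, as compound 2 has no value to serve as its starting point. Nothing in the data shown accounts for the difference between the methyl and the hydrogen.

On these data alone, it remains open whether an ethyl or a trifluoromethyl on that aromatic carbon would go further than the methyl. As far as these compounds go, it is equally open how a fluoro or an ethoxy in place of the methoxy, para to a large group, would read.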